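Dichlorophenyl Swap on an Amine Nitrogen in a Naphthoquinone Series

The source may hold more compounds than are shown below. What is called first, only, known or untested is meant among the compounds shown, and "the series" means these compounds.

Compound 1 `COc1ccc(N/C(CCNC2=CC(=O)c3ccccc3C2=O)=N\S(=O)(=O)c2ccc(C)cc2)cc1` is one of three close analogues that share a core and differ only in the aryl group on an amine nitrogen. In a functional assay on DU-145 cells (Homo sapiens) for cytotoxicity, read by MTT assay, with a stated time of 48 h (a higher number here means a weaker inhibitor, a lower number a stronger inhibitor), compound 1 gives 12000 nM, the upper end of a group whose values all sit within the usual scatter of one another: compound 2 `Cc1ccc(S(=O)(=O)/N=C(/CCNC2=CC(=O)c3ccccc3C2=O)Nc2ccccc2I)cc1` gives 11700 nM and compound 3 `Cc1ccc(S(=O)(=O)/N=C(/CCNC2=CC(=O)c3ccccc3C2=O)Nc2cccc(C)c2)cc1` gives 10200 nM. The steps of a 1.0-fold lower number from compound 1 to compound 2 (0.01 log units; within the scatter) and a 1.2-fold lower number from compound 1 to compound 3 (0.07 log units; within the scatter) are both within the scatter. Compound 4 `Cc1ccc(S(=O)(=O)/N=C(/CCNC2=CC(=O)c3ccccc3C2=O)Nc2ccc(Cl)cc2Cl)cc1` carries the change (2,4-dichlorophenyl in place of 4-methoxyphenyl on an amine nitrogen). Because a 1.0-fold lower number from compound 1 to compound 2 (0.01 log units; within the scatter) and a 1.2-fold lower number from compound 1 to compound 3 (0.07 log units; within the scatter) show the aryl swaps leaving this assay untouched, compound 4 is expected to show a 1.1-fold lower number from compound 1 to compound 4 (0.04 log units; within the scatter), a step within the scatter. Compound 4 is estimated at 11000 nM, within 6000 nM to 22000 nM.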

Compound 4, half-maximal inhibitory concentration: 18600 nM
Beside the measured number, compound 4's estimate is 1.7-fold (0.23 log units) below it, and the stated range covers the measured number.
By their numbers in this assay, from the lowest: compounds 3, 2, 1 and 4 (each within the scatter of the next).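

In this assay, the 2,4-dichlorophenyl group brings two chlorine atoms onto the aryl ring on the amine nitrogen, and this swap also stays within the scatter. The steps of a 1.6-fold higher number from compound 1 to compound 4 (0.19 log units; within the scatter) and a 1.6-fold higher number from compound 2 to compound 4 (0.20 log units; within the scatter) and a 1.8-fold higher number from compound 3 to compound 4 (0.26 log units; within the scatter) show that all four aryl groups give values that cannot be told apart at this position. Nothing available explains the values of these compounds. From the compounds shown here alone, whether a cyclohexyl group in place of the aryl ring, or an amine or a carboxylic acid on that ring, would move the number beyond the scatter remains open.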